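The compounds below may be only part of what the source reports. "The series", "measured", "known", "first", "only" and "open" are said of these compounds alone.

Measured in a functional assay on MCF7 cells (Homo sapiens) for antiproliferative activity, read by MTT assay, with a stated time of 72 h; on this read-out lower numbers stand for stronger inhibition and higher numbers for weaker inhibition:
- Compound 1 `CC(=O)O[C@H]1CC[C@]2(C)[C@H](CC[C@@](C)(O)[C@H]2CC[C@@H]2C(C)=CC[C@H]3[C@H](CC[C@]3(C)O)C2(C)C)OC1(C)C`: 47900 nM
- Compound 2 `CC1=CC[C@H]2[C@H](CC[C@]2(C)O)C(C)(C)[C@@H]1CC[C@H]1[C@]2(C)CC[C@H](OC(=O)CCC(=O)O)C(C)(C)O[C@H]2CC[C@@]1(C)O`: > 50000 nM, a limit of the assay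
- Compound 3 `CC1=CC[C@H]2[C@H](CC[C@]2(C)O)C(C)(C)[C@@H]1CC[C@H]1[C@]2(C)CC[C@H](OC(=O)c3ccccc3)C(C)(C)O[C@H]2CC[C@@]1(C)O`: 21000 nM

Compound 3 has the lower of the two actual numbers, and its nearest neighbour is compound 1 at 47900 nM. Compound 2 gives only a limit.

Compound 4 `CC1=CC[C@H]2[C@H](CC[C@]2(C)O)C(C)(C)[C@@H]1CC[C@H]1[C@]2(C)CC[C@H](OC(=O)c3ccncc3)C(C)(C)O[C@H]2CC[C@@]1(C)O` carries pyridin-4-yl in place of phenyl on a carbonyl carbon, a change from benzoyl to (pyridin-4-yl)carbonyl: pyridin-4-yl in place of phenyl on a carbonyl carbon.

Two measured steps act on this same carbonyl carbon. Phenyl replaces methyl in a 2.3-fold lower number from compound 1 to compound 3 (0.36 log units; beyond the scatter), and it replaces 2-carboxyethyl in an at least 2.3-fold lower number from compound 2 to compound 3 (0.37 log units; beyond the scatter). Both steps are small, and neither tests a pyridin-4-yl ring. Only a small rise in this assay is therefore expected, probably not beyond the scatter, with the phenyl gain of compound 3 partly kept. The expected step is a 1.4-fold higher number from compound 3 to compound 4 (0.15 log units; within the scatter). For compound 4 the estimated value is 30000 nM, with an expected range of 13000 nM to 60000 nM.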

Compound 4, half-maximal inhibitory concentration: 25300 nM
Beside the measured number, compound 4's estimate is 1.2-fold (0.07 log units) above it, within the range that was stated.
By their numbers in this assay, from the lowest: compounds 3, 4 and 1 (each within the scatter of the next, the first and the last beyond it). At a limit, above all of these: compound 2.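

In this assay, within the data shown here, this carbonyl carbon now carries a ring with a hetero atom for the first time, and replacing phenyl with pyridin-4-yl gives a 1.2-fold higher number from compound 3 to compound 4 (0.08 log units; within the scatter), so the added hydrogen-bond acceptor brings no change beyond the scatter. Pyridin-4-yl in place of methyl gives a 1.9-fold lower number from compound 1 to compound 4 (0.28 log units; within the scatter) and so does not repeat the step seen with phenyl, which was a 2.3-fold lower number from compound 1 to compound 3 (0.36 log units; beyond the scatter). Set against 2-carboxyethyl, pyridin-4-yl gives an at least 1.9-fold lower number from compound 2 to compound 4 (0.29 log units; that floor lies within the scatter), a reading that rests on a limit of the assay: the limit of > 50000 nM in this assay, at which 1 of the 4 values shown sits.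

Going by these compounds, whether a pyridin-2-yl or pyridin-3-yl ring on this carbonyl carbon would behave as pyridin-4-yl does stays open. So does whether a benzoyl ring carrying a methoxy group or a dimethylamino group would move the number beyond the scatter.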